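The source may hold more compounds than are shown below. What is called first, only, known or untested is meant among the compounds shown, and "the series" means these compounds.

Compound 1 `CC1(C)C(=O)Nc2nc(-n3nc(CCCC(F)(F)F)c4cc(Cl)ccc43)nc(N)c21` is the weakest of three compounds measured in an assay on CHO cells for activation of soluble guanylate cyclase alpha1/beta1 complex (Homo sapiens), read by cGMP accumulation; a higher number here means that more compound is needed for the effect, a lower number that less compound is needed: compound 1 gives 117000 nM, compound 2 `COC(=O)N(C)c1c(N)nc(-c2nc(Cc3ccccc3F)n3ccccc23)nc1N` gives 20400 nM, and compound 3 `COC(=O)N(C)c1c(N)nc(-n2nc(Cc3ccccc3F)c3ccccc32)nc1N` gives 310 nM. Compound 4 `CC1(C)C(=O)Nc2nc(-n3nc(Cc4c(F)ccc(F)c4F)c4cc(Cl)ccc43)nc(N)c21` differs from compound 1 by 2,3,6-trifluorophenyl in place of 3,3,3-trifluoropropyl on a saturated chain carbon bound to an aromatic carbon on the shared core. Within the data shown here, no directly comparable step between measured compounds exists, so the expectation rests on what the other numbers show: compound 3 carries a fluorinated benzyl group and gives a far lower number than compound 1 or compound 2, although its core is different. Compound 4 is therefore expected to need less compound than compound 1, by a step of a 15-fold lower number from compound 1 to compound 4 (1.17 log units; beyond the scatter) in this assay. The estimate for compound 4 is 8000 nM, with a likely range from 1500 nM to 40000 nM.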

Compound 4, half-maximal effective concentration: 7300 nM
For compound 4 the middle estimate is 1.1-fold (0.04 log units) above the measured one; measured number inside the range.
By their numbers in this assay, from the lowest: compound 3; then compound 4; then compound 2; then compound 1.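

On the shared core, the group on a saturated chain carbon bound to an aromatic carbon strongly affects the result in this assay: 2,3,6-trifluorophenyl in place of 3,3,3-trifluoropropyl gives a 16-fold lower number from compound 1 to compound 4 (1.20 log units; beyond the scatter). The fluorine count stays the same in this change, while a six-membered aromatic ring enters where no ring stood. Nothing shown here accounts for the step. The compounds shown leave open whether the ring alone carries this step; a plain phenyl at this place would separate the ring from its fluorines.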